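The source may hold more compounds than are shown below. What is called first, only, known or untested is meant among the compounds shown, and "the series" means these compounds.

Compound 2 `Cc1cc(C(=O)c2ccc(F)cc2)ccc1OCC(=O)Nc1nc(-c2ccccc2)cs1` is the starting point here. In a functional assay on DLA cells (Mus musculus) for cytotoxicity, read by trypan blue exclusion, with a stated time of 48 h (on this read-out lower numbers stand for stronger inhibition and higher numbers for weaker inhibition), compound 2 gives 32100 nM, the highest number of the three measured compounds. Compound 1 `Cc1ccc(C(=O)c2ccc(OCC(=O)Nc3nc(-c4ccccc4)cs3)c(C)c2)cc1` gives 25000 nM, and the step of a 1.3-fold higher number from compound 1 to compound 2 (0.11 log units; within the scatter) means the two cannot be told apart. Compound 3 `COc1ccc(-c2csc(NC(=O)COc3ccc(C(=O)c4ccc(F)cc4)cc3C)n2)cc1` gives 5000 nM, and the step of a 6.4-fold lower number from compound 2 to compound 3 (0.81 log units; beyond the scatter) is the only clear movement among these three.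

Compound 4 `Cc1cc(C(=O)c2ccccc2F)ccc1OCC(=O)Nc1nc(-c2ccccc2)cs1` is built from the same atoms as compound 2, joined differently: 2-fluorophenyl in place of 4-fluorophenyl on a carbonyl carbon. The fluorine stays on the same phenyl ring but moves to another carbon of it.

Among the measured compounds shown here, only one measured step touches that 4-fluorophenyl group: the change from compound 1 to compound 2, which swapped a methyl for a fluoro on it, and a 1.3-fold higher number from compound 1 to compound 2 (0.11 log units; within the scatter) stayed within the scatter. The step to compound 3 concerns a different ring and says nothing about the fluorine. Moving a fluorine within a ring whose earlier substituent swap made no clear difference gives no grounds for expecting a clear shift in either direction.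

The expected step from compound 2 to compound 4 is therefore a 1.0-fold lower number from compound 2 to compound 4 (0.00 log units; within the scatter), within the scatter. Compound 4 is expected to give about 32000 nM, in a range from 14000 nM to 75000 nM.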

Compound 4, half-maximal inhibitory concentration: 13700 nM
Compound 4: middle estimate off by 2.3-fold (0.37 log units), on the high side; measured number outside the range, below it.
By their numbers in this assay, from the lowest: compound 3; then compounds 4, 1 and 2 (each within the scatter of the next, the first and the last beyond it).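

Moving the fluorine within the ring on the carbonyl carbon gives a 2.3-fold lower number from compound 2 to compound 4 (0.37 log units; beyond the scatter) in this assay and so counts for more than the earlier swap on that ring, which gave only a 1.3-fold higher number from compound 1 to compound 2 (0.11 log units; within the scatter) and could not be told from scatter. The gain is limited, though: replacing 4-methylphenyl with 2-fluorophenyl gives a 1.8-fold lower number from compound 1 to compound 4 (0.26 log units; within the scatter) and stays within the scatter, so only compound 2 and compound 4 stand clearly apart, while compound 1 cannot be separated from either. Thus, the place of the fluorine on this ring can matter on this read-out, but no measurement shown here offers an explanation for the shift.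

On these data alone, the methoxy group of compound 3 sits on a different ring, and whether it and the 2-fluorophenyl group would together give a lower number than either does alone remains open. As far as these compounds go, it is also open how this position would respond to a group other than fluorine or methyl on the ring, such as an amine or a carboxylic acid.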